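Sulfonyl aryl exchange on the shared core

The compounds below may be only part of what the source reports. "The series", "measured", "known", "first", "only" and "open" are said of these compounds alone.

Measured compounds:
compound 1 `Cc1ccc(S(=O)(=O)c2cc3cnc(Nc4ccc5[nH]ccc5c4)nc3n(C)c2=O)cc1`: 750 nM
compound 2 `Cc1ccc(S(=O)(=O)c2cc3cnc(Nc4cccc5cccnc45)nc3n(C)c2=O)cc1`: 10000 nM

Compound 1 is the lower of the two numbers in a functional assay on DU-145 cells (Homo sapiens) for inhibition, read by trypan blue exclusion, with a stated time of 72 h; a higher number here means a weaker inhibitor, a lower number a stronger inhibitor; compound 2 sits a full step away, a 13-fold higher number from compound 1 to compound 2 (1.12 log units; beyond the scatter), and that step concerns the nitrogen on the aromatic ring, where quinolin-8-yl replaces 1H-indol-5-yl.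

Compound 3 `Cn1c(=O)c(S(=O)(=O)c2ccc(Cl)cc2Cl)cc2cnc(Nc3ccc4[nH]ccc4c3)nc21` keeps the 1H-indol-5-yl of compound 1 and alters a different place: 2,4-dichlorophenyl in place of 4-methylphenyl on a sulfonyl sulfur. Among the compounds with values here, no measured step touches the sulfonyl aryl, so the one recorded step gives no direction for this change; it shows only that a replacement elsewhere on the shared core can move this assay by a large amount. With nothing comparable at the sulfonyl sulfur, the expectation is no step beyond the scatter, i.e. compound 3 is estimated to land near compound 1, a 1.1-fold higher number from compound 1 to compound 3 (0.03 log units; within the scatter), with a wide range to allow for the lack of precedent. Compound 3 is therefore estimated at 800 nM, between 250 nM and 2500 nM.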

Compound 3, half-maximal inhibitory concentration: 1000 nM
Estimate against measurement, compound 3: 1.3-fold (0.10 log units) below; the measured number falls inside the stated range.
By their numbers in this assay, from the lowest: compounds 1 and 3 (each within the scatter of the next); then compound 2.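

In this assay, within the data shown here, the first exchange at the sulfonyl sulfur, 2,4-dichlorophenyl in place of 4-methylphenyl, gives a 1.3-fold higher number from compound 1 to compound 3 (0.12 log units; within the scatter) with the 1H-indol-5-yl held constant, so this position has now been probed and this one change stays inside the scatter. The series therefore has a contrast it lacked before: the exchange on the nitrogen on the aromatic ring gives a 13-fold higher number from compound 1 to compound 2 (1.12 log units; beyond the scatter) as a large step, whereas this exchange on the sulfonyl sulfur, with one more heavy atom and two chlorine atoms entering, leaves the reading effectively unchanged. No supporting data on the compounds accompany this result, so the flat step remains an observation without an explanation.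

Going by these compounds, the two aryl groups compared are both six-membered aromatic rings of carbon only, without hydrogen-bond donors or acceptors, so the effect of an amine or a carboxylic acid on that phenyl ring remains open. Also open, on these data alone, is whether 2,4-dichlorophenyl would behave the same way on the sulfonyl sulfur with quinolin-8-yl in place of 1H-indol-5-yl.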